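A few compounds are considered here, and "the series" means these few. Any claim that something is new, unique, unknown or untested is made for them only; others in the source may bear on it.

Compound 1 `COC(=O)NC1=CS(=O)(=O)O[C@@]12[C@@H](CO[Si](C)(C)C(C)(C)C)O[C@@H](n1cc(C)c(=O)n(C)c1=O)[C@@H]2O[Si](C)(C)C(C)(C)C` is the point of departure. In a functional assay on MT4 cells (Homo sapiens) (on this read-out higher numbers stand for lower toxicity in this test and lower numbers for higher toxicity in this test), compound 1 gives 29900 nM, the lowest of the three numbers measured here, with compound 2 and compound 3 both standing beyond the scatter above it. Compound 2 `Cc1cn([C@@H]2O[C@@H]3COC4(O)CS(=O)(=O)O[C@@]34[C@H]2O)c(=O)[nH]c1=O` gives 100000 nM in this assay, and compound 3 `Cc1cn([C@@H]2O[C@@H]3COC4(O)CS(=O)(=O)O[C@@]34[C@H]2O[Si](C)(C)C(C)(C)C)c(=O)[nH]c1=O` gives 100000 nM. Among the compounds with values here, the single one-place step between measured compounds, no change at the digits printed from compound 2 to compound 3 (within the scatter), concerns an oxygen on a saturated carbon and not the amine nitrogen that is changed here, so it offers only an indirect guide: a sizeable addition at one position left the read-out unchanged.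

Compound 4 `Cc1cn([C@@H]2O[C@H](CO[Si](C)(C)C(C)(C)C)[C@@]3(OS(=O)(=O)C=C3NCCC(N)=O)[C@H]2O[Si](C)(C)C(C)(C)C)c(=O)n(C)c1=O` differs from compound 1 by 2-carbamoylethyl in place of methoxycarbonyl on an amine nitrogen. Within the data shown here, no measured pair shows what this exchange does in this assay. Among the measured compounds shown here, with no direct precedent and one flat step elsewhere, the step of a 1.0-fold higher number from compound 1 to compound 4 (0.00 log units; within the scatter) is expected to remain within the scatter. The estimate for compound 4 is 30000 nM, expected to lie between 10000 nM and 100000 nM.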

Compound 4, half-maximal cytotoxic concentration: 20000 nM
For compound 4 the middle estimate is 1.5-fold (0.18 log units) above the measured one; the measured number falls inside the stated range.
By their numbers in this assay, from the lowest: compounds 4 and 1 (each within the scatter of the next); then compounds 2 and 3 (each within the scatter of the next).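

In this assay, within the data shown here, replacing methoxycarbonyl with 2-carbamoylethyl on the amine nitrogen gives a 1.5-fold lower number from compound 1 to compound 4 (0.17 log units; within the scatter), the first direct reading of a change at this position. The swap brings in a nitrogen and a hydrogen-bond donor and removes the ester-type group, yet the two compounds cannot be told apart on this read-out, so this position tolerates at least this one exchange without a change beyond the scatter. No supporting measurement is available to explain this result.

The compounds shown leave open whether a longer chain, a carboxylic acid or a simple primary amine on this nitrogen would also stay within the scatter of compound 1. A single pair also cannot show whether the same exchange would read the same way on a different core.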